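This account rests on a few compounds, and the source may have more. Where it says the series, first, only, none or still open, it means among the compounds named here.

In an ADME assay on microsomes from liver (Rattus norvegicus, strain Crj;CD(SD)) for metabolic stability, read by LC-MS, using NADPH, with a stated time of 30 min, tested at 0.1 uM (a higher number here means that more of the compound is left, a lower number that less of the compound is left), compound 3 (`Cc1cc(C#N)cnc1C(=O)Nc1ccc(F)c([C@]2(C)C=C(CF)OC(N)=N2)c1`) gives 34% as the lowest of the three numbers, with compound 2 (`C[C@@]1(c2cc(NC(=O)c3ncc(C#N)cc3Cl)ccc2F)C=C(CF)OC(N)=N1`) at 49% and compound 1 (`C[C@@]1(c2cc(NC(=O)c3cnc(OCF)cn3)ccc2F)C=C(CF)OC(N)=N1`) at 52% on the same scale. Compound 4 (`C[C@@]1(c2cc(NC(=O)c3coc(C(F)F)n3)ccc2F)C=C(CF)OC(N)=N1`) is reached from compound 3 by a single exchange (2-(difluoromethyl)-1,3-oxazol-4-yl in place of 5-cyano-3-methylpyridin-2-yl on a carbonyl carbon). Of the measured steps, a number 3 percentage points lower from compound 1 to compound 2 (within the scatter) stays within the scatter, whereas a number 18 percentage points lower from compound 1 to compound 3 (beyond the scatter) and a number 15 percentage points lower from compound 2 to compound 3 (beyond the scatter) are modest, so leaving the 5-cyano-3-methylpyridin-2-yl of compound 3 is expected to bring a modest rise in this assay although the entering group itself is unmeasured. The estimated step is a number 12 percentage points higher from compound 3 to compound 4 (beyond the scatter) as an expectation only. For compound 4 the expected value is 46% (estimated range 30% to 62%).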

Compound 4, percent of the compound remaining: 57%
Estimate against measurement, compound 4: 11 percentage points below; the measured number falls inside the stated range.
By their numbers in this assay, from the lowest: compound 3; then compounds 2, 1 and 4 (each within the scatter of the next).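

In this assay, a five-membered aromatic ring on the carbonyl carbon, 2-(difluoromethyl)-1,3-oxazol-4-yl, gives a number 23 percentage points higher from compound 3 to compound 4 (beyond the scatter), so a six-membered aromatic ring is not needed at this place for a number of this size. The change stands out only against the 5-cyano-3-methylpyridin-2-yl, since a number 8 percentage points higher from compound 2 to compound 4 (within the scatter) and a number 5 percentage points higher from compound 1 to compound 4 (within the scatter) both stay within the scatter. No evidence is available that bears on this result. As far as these compounds go, whether the number depends on the difluoromethyl or on the oxazole ring itself stays open, and a methyl or a trifluoromethyl in its place would separate the two.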